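The source may hold more compounds than are shown below. What is called first, only, known or untested is meant among the compounds shown, and "the series" means these compounds.

In a toxicity assay on cells (Erythrocyte, Mus musculus) for activation, read by spectrophotometry and hemolysis, with a stated time of 30 min (a higher number here means that more compound is needed for the effect, a lower number that less compound is needed), compound 1 `Clc1ccc(/C=N/Nc2nc3ccccc3s2)cc1` gives > 200 ug/mL, which is a limit of the assay and not a number. Compound 2 `Brc1ccc(/C=N/Nc2nc3ccccc3s2)cc1` gives > 200 ug/mL in this assay, which is again only a limit. For the measured compounds named here, compound 2 therefore stands without a measured number, and the series so far offers only (the limit of > 200 ug/mL in this assay, at which 2 of the 2 values shown sit).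

Compound 3 `C(=N/Nc1nc2ccccc2s1)\c1ccc(-c2ccccn2)cc1` brings pyridin-2-yl in place of bromo on an aromatic carbon. Going by the values given here, the one measured step that bears on this change is a step that the two limits leave unreadable from compound 1 to compound 2. That exchange of bromo for chloro gives no size to carry over, and it does not involve a ring entering the structure. No step beyond the scatter can be argued for in this assay, in either direction. The expectation rests on (the limit of > 200 ug/mL in this assay, at which 2 of the 2 values shown sit), shared by compound 1 and compound 2, and the assay may well report only a limit once more. The estimated step is a number no higher from compound 2 to compound 3 (the limit leaves the size open), which is expected to stay within the scatter. Compound 3 is estimated at 200 ug/mL, with an expected range from 100 ug/mL to 400 ug/mL.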

Compound 3, half-maximal effective concentration: > 200 ug/mL
Compound 3 was reported as a limit (the forecaster's own chance of this, stated with the estimate: 80%); the middle value lies on the limit itself.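

In this assay compound 3 gives > 200 ug/mL, again a limit and not a number, so its steps to compound 1 and compound 2 cannot be read. The compounds shown leave open at what concentration any of them reaches the half-maximal effect, and whether chloro, bromo and pyridin-2-yl differ at all, with only this to go on: the limit of > 200 ug/mL in this assay, at which 3 of the 3 values shown sit.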